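Cyclohexyl for phenyl on the ring amide nitrogen

This account rests on a few compounds, and the source may have more. Where it says the series, first, only, none or still open, it means among the compounds named here.

Two members of the series have been run in a functional assay on MCF7 cells (Homo sapiens) for antiproliferative activity, read by MTT assay, with a stated time of 72 h (on this read-out lower numbers stand for stronger inhibition and higher numbers for weaker inhibition), so far, and neither produced a number. Compound 1 `O=C1COc2ccc(-c3cnc(Cl)c(NS(=O)(=O)c4ccc(F)cc4)c3)cc2N1c1ccccc1` reaches only the ceiling of this assay, > 40000 nM, which is a limit rather than a measured value. Compound 2 `O=C1COc2ccc(-c3cnc4ccccc4c3)cc2N1c1ccccc1` likewise sits at the limit in this assay, > 40000 nM. Both readings fall on the same line: the limit of > 40000 nM in this assay, at which 2 of the 2 values shown sit. Compound 2 therefore has no place on a numerical scale; all that is known is that its inhibition, if any, lies beyond the range of the assay, and the same holds for compound 1.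

Compound 3 `O=C1COc2ccc(-c3cnc4ccccc4c3)cc2N1C1CCCCC1` differs from compound 2 in a single place: cyclohexyl in place of phenyl on an amide-type nitrogen in a ring. Within the data shown here, no step between two measured compounds is available for this change, and neither measured compound supplies a number from which to move. For the step of a number no higher from compound 2 to compound 3 (the limit leaves the size open) the expectation is no change beyond the scatter. Compound 3 is expected to give roughly 40000 nM in this assay, within a range from 15000 nM to 100000 nM, and the most probable outcome is that the assay again returns only a limit.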

Compound 3, half-maximal inhibitory concentration: > 40000 nM
Compound 3: no number, only a limit; the forecaster's own chance of this, stated with the estimate: 85%; the middle value lies on the limit itself.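

In this assay compound 3 gives > 40000 nM, which is a limit. Compound 2 also stands at a limit, so no step can be read between compound 2 and compound 3 for cyclohexyl in place of phenyl. The compounds shown leave open whether any member of the series gives a measurable inhibition: the limit of > 40000 nM in this assay, at which 3 of the 3 values shown sit.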